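A few compounds are considered here, and "the series" means these few. Any claim that something is new, unique, unknown or untested is made for them only; others in the source may bear on it.

Measured so far in a functional assay on Huh7.5.1 cells (Homo sapiens) for cytotoxicity, read by MTT assay, with a stated time of 72 h; a higher number here means that more compound is tolerated, a lower number that less compound is tolerated:
Compound 1 `C=c1[nH]c(=O)/c(=C/c2ccccc2)[nH]c1=O`: > 20000 nM, a limit.
Compound 2 `C=c1[nH]c(=O)/c(=C/c2ccc(C(F)(F)F)cc2)[nH]c1=O`: > 20000 nM, a limit.

Compound 1 has no numerical value on this read-out. Compound 1 stands at the limit of > 20000 nM. The next change leads to compound 3 `C=c1[nH]c(=O)/c(=C/c2ccc(-c3ccccc3)cc2)[nH]c1=O`: phenyl in place of hydrogen on an aromatic carbon, which places phenyl in place of hydrogen on an aromatic carbon.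

For the measured compounds named here, one measured step bears on this change, since it also replaces hydrogen on an aromatic carbon: a step that the two limits leave unreadable from compound 1 to compound 2. Its size cannot be read, and the evidence consists only of the limit of > 20000 nM in this assay, at which 2 of the 2 values shown sit. That step therefore gives no direction for compound 3, and it sets no size.

With nothing pointing either way, no step beyond the usual scatter is expected in this assay. The expected step is a number no higher from compound 1 to compound 3 (the limit leaves the size open). Another report at the limit is the most likely outcome, although the larger phenyl group has not been tested on this core. For compound 3 the half-maximal cytotoxic concentration is estimated at 20000 nM, with an expected range of 9000 nM to 40000 nM.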

Compound 3, half-maximal cytotoxic concentration: > 20000 nM
Compound 3 gave a limit, no number (the forecaster's own chance of this, stated with the estimate: 70%); the middle value sits exactly at the limit.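

The steps among compound 1, compound 2 and compound 3 cannot be read in this assay, since each result is a limit and not a number: the limit of > 20000 nM in this assay, at which 3 of the 3 values shown sit. The compounds shown leave open whether any group at this place on the shared core gives a numerical half-maximal cytotoxic concentration, and how far each compound's true value lies from the limit.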